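Replacing the Diethylamino Group in Compound 2

A few compounds are considered here, and "the series" means these few. Any claim that something is new, unique, unknown or untested is made for them only; others in the source may bear on it.

Of the compounds shown here, two have so far been tested in a functional assay on SK-MEL-5 cells (Homo sapiens) for inhibition, with a stated time of 72 h; on this read-out lower numbers stand for stronger inhibition of growth and higher numbers for weaker inhibition of growth. Compound 1 (`CCc1c(C(=O)NCc2c(O)ccc3cccc(O)c23)[nH]c(C)c1C(C)=O`) gives 4200 nM. Compound 2 (`CCN(CC)S(=O)(=O)c1ccc(OC)c(NC(=O)c2[nH]c(C)c3c2CCCCC3=O)c1`) gives 16300 nM, the higher of the two numbers, which means weaker inhibition of growth, and the gap between them lies beyond the usual scatter. Compound 3 (`COc1ccc(S(=O)(=O)N2CC3(COC3)C2)cc1NC(=O)c1[nH]c(C)c2c1CCCCC2=O`) keeps the rest of compound 2 but changes what sits on a sulfonyl sulfur: a group of 7 heavy atoms (5 carbon, 1 nitrogen, 1 oxygen; 2 four-membered non-aromatic rings with 1 hetero atom each) in place of a group of 5 heavy atoms (4 carbon, 1 nitrogen; no ring), on a sulfonyl sulfur. The diethylamino group leaves, and a group with two four-membered non-aromatic rings enters. Going by the values given here, no measured pair shows the effect of such a swap, and the two measured compounds differ too widely to serve as a guide. The expected result is therefore a step within the scatter, estimated as a 1.1-fold higher number from compound 2 to compound 3 (0.04 log units; within the scatter). For compound 3 the estimated value is 18000 nM, with an expected range from 7000 nM to 45000 nM.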

Compound 3, concentration for 50% growth inhibition: 20800 nM
For compound 3 the middle estimate is 1.2-fold (0.06 log units) below the measured one, and the stated range covers the measured number.
By their numbers in this assay, from the lowest: compound 1; then compounds 2 and 3 (each within the scatter of the next).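

In this assay, placing the group with two four-membered non-aromatic rings on the sulfonyl sulfur in place of the diethylamino group gives a 1.3-fold higher number from compound 2 to compound 3 (0.11 log units; within the scatter), a step within the scatter. Going by these compounds alone, this is the first pair that differs in one place, and it shows that this position can carry a group of 7 heavy atoms, with two rings and a hydrogen-bond acceptor, without a clear change in the read-out. Nothing measured here offers an explanation for this result.

Going by these compounds, whether a morpholine or piperidine ring, or a primary amine, on the sulfonyl sulfur would move the number beyond the scatter remains open. Compound 1 differs from compound 2 and compound 3 in more than one place, so its value cannot be tied to any single group.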